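Chloro-to-methoxy step across two scaffolds

The source may report more compounds than this note shows. Statements on the series, on what has been measured and on what is new or still open speak of the compounds shown alone.

Measured compounds:
compound 1 `CN1C(=O)[C@@]2(c3ccccc31)N(C)C[C@@H](c1ccc(Cl)cc1)[C@@]21Cc2ccccc2C1=O` gives 86.6%
compound 2 `COc1ccc([C@@H]2CN(C)[C@]3(C(=O)N(C)c4ccccc43)[C@]23Cc2ccccc2C3=O)cc1` gives 82.3%
compound 3 `Cc1ccc(NC(=O)c2c(-c3ccc(Cl)cc3)cc(-c3ccccc3)nc2Nc2ccc(Cl)cc2)cc1` gives 58%

All three were tested in a functional assay on RPMI18226 cells (Homo sapiens) for antiproliferative activity, read by sulforhodamine B assay, with a stated time of 48 h, tested at 10 uM; on this read-out higher numbers stand for more inhibition at the one concentration tested (going by the name of the read-out) and lower numbers for less inhibition. Compound 1 and compound 2 share one core and differ by methoxy in place of chloro on an aromatic carbon; the step of a number 4.3 percentage points lower from compound 1 to compound 2 (within the scatter) is within the scatter, so the two cannot be ordered. Compound 3 sits on a different core, and the difference between the two cores is not broken down here; its number is the lowest of the three, beyond the scatter from both compound 1 and compound 2.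

Compound 4 `COc1ccc(Nc2nc(-c3ccccc3)cc(-c3ccc(Cl)cc3)c2C(=O)Nc2ccc(C)cc2)cc1` is not yet measured. It differs from compound 3 by methoxy in place of chloro on an aromatic carbon, the same change as that between compound 1 and compound 2, since the two place descriptions are the same word for word. Among the compounds with values here, only one earlier instance of the change exists, on another core, which limits what can be carried over. Given that compound 1 to compound 2 moved by a number 4.3 percentage points lower from compound 1 to compound 2 (within the scatter), the expected step of a number 3 percentage points lower from compound 3 to compound 4 (within the scatter) is estimated to be small in the same direction. Compound 4 is therefore expected near 55%, estimated between 38% and 70% in this assay.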

Compound 4, a percentage reported as inhibition, at one concentration (the size of the read-out at that concentration, not a potency): 79%
The estimate for compound 4 lay 24 percentage points below the measured number, and the stated range ends below it.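

In this assay, methoxy in place of chloro on an aromatic carbon gives a number 21 percentage points higher from compound 3 to compound 4 (beyond the scatter), so on the core of compound 3 the change shifts the read-out clearly, whereas on the core of compound 1 it gave no shift that can be read. The step therefore does not carry over in size from one core to the other: the same change on two cores in this assay, a number 4.3 percentage points lower (within the scatter) from compound 1 to compound 2 and a number 21 percentage points higher (beyond the scatter) from compound 3 to compound 4, 25.3 percentage points apart, beyond the scatter of two such steps These two instances show only that the result of this change differed between these two cores; they do not show which feature of either core accounts for the gap, how the change would behave on a third core, or how potency compares, since the read-out comes from a single concentration.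

Open, on these data alone, is whether the rise on the core of compound 3 is specific to methoxy or would also appear with an ethoxy group, an amine or a carboxylic acid in the same place. Also open, as far as these compounds go, is whether the same swap at the 4-chlorophenyl group that compound 4 retains would give a similar step.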